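The source may hold more compounds than are shown below. What is called first, only, known or untested is meant among the compounds shown, and "the series" means these compounds.

Working notes on the series, step from compound 2 to compound 3.

Two compounds carry a number in a functional assay on MCF7 cells (Homo sapiens) for cytotoxicity, read by MTT assay, with a stated time of 24 h, tested at 1.6 ug/mL; a lower number here means a weaker effect, a higher number a stronger effect of the compound at the concentration tested. Compound 1 `Cc1ccc2oc(SCC(=O)Nc3ccc(-c4nc(-c5ccccc5)c(-c5ccccc5)n4C)cc3)nc2c1` gives 1.9% in this assay. Going by the values given here, compound 2 `Cn1ccnc1SCC(=O)Nc1ccc(-c2nc(-c3ccccc3)c(-c3ccccc3)n2C)cc1` gives 17.5% in this assay, the higher of the two numbers; its nearest neighbour is compound 1, and the single step recorded, a number 15.6 percentage points higher from compound 1 to compound 2 (beyond the scatter), lies beyond the scatter but stays modest in size.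

Compound 3 `CN1CCN(CC(=O)Nc2ccc(-c3nc(-c4ccccc4)c(-c4ccccc4)n3C)cc2)CC1` is the unmeasured member. Its difference from compound 2 is 4-methylpiperazin-1-yl in place of (1-methyl-1H-imidazol-2-yl)sulfanyl on a saturated chain carbon bound to a carbonyl carbon. Among the compounds with values here, no measured step touches this kind of exchange: the one step in hand alters the aromatic ring on the sulfur, while here the whole (1-methyl-1H-imidazol-2-yl)sulfanyl group departs and 4-methylpiperazin-1-yl enters on the saturated chain carbon bound to the carbonyl carbon. Within the data shown here, the only guidance is that both measured numbers sit low and the one recorded step is modest, so a change of similar or smaller size, in either direction, is expected in this assay.

Compound 3 is therefore estimated at 14% in this assay, with a range from 2% to 32%, which corresponds to an expected step of a number 3.5 percentage points lower from compound 2 to compound 3 (within the scatter).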

Compound 3, a percentage reported as activity, at one concentration (the size of the read-out at that concentration, not a potency): 2.9%
Beside the measured number, compound 3's estimate is 11.1 percentage points above it; measured number inside the range.
By their numbers in this assay, from the lowest: compounds 1 and 3 (each within the scatter of the next); then compound 2.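

In this assay the exchange of the whole sulfanyl group on the saturated chain carbon bound to a carbonyl carbon gives a number 14.6 percentage points lower from compound 2 to compound 3 (beyond the scatter) and so shows that this place also responds when the sulfur and its aromatic ring leave together, not only when the ring on the sulfur changes. The matching exchange from the other sulfanyl group gives a number 1 percentage points higher from compound 1 to compound 3 (within the scatter) and so leaves compound 2 as the only one of the three beyond the scatter of the others, while compound 1 keeps a sulfur and still cannot be told apart from compound 3, which has none, so the sulfur alone does not go with the higher number. Nothing available bears on the reason for these differences.

The compounds shown leave open whether the higher number of compound 2 belongs to the 1-methyl-1H-imidazol-2-yl ring itself or would persist with another ring on the sulfur, such as a 1,2,4-triazol-3-yl ring. They also leave open how a morpholin-4-yl group or an open-chain dimethylamino group would read at this place, and whether any of these numbers would shift at other concentrations.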